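Carbonyl aryl replacement and cytotoxicity: toward compound 4

The source may hold more compounds than are shown below. What is called first, only, known or untested is meant among the compounds shown, and "the series" means these compounds.

Measured so far:
compound 1, `COc1cc(-c2nnc3n2NC(c2ccco2)C(C(=O)c2ccc(F)c(F)c2)S3)cc(OC)c1OC`: 52400 nM
compound 2, `COc1cc(-c2nnc3n2NC(c2ccco2)C(C(=O)c2ccc(Cl)cc2)S3)cc(OC)c1OC`: 78600 nM
compound 3, `COc1cccc(C(=O)C2Sc3nnc(-c4cc(OC)c(OC)c(OC)c4)n3NC2c2ccco2)c1`: reported only as a limit, > 100000 nM

In a functional assay on HepG2 cells (Homo sapiens) for cytotoxicity, read by MTT assay, with a stated time of 48 h (a lower number here means a stronger inhibitor, a higher number a weaker inhibitor), compound 1 holds the lowest of the two numbers given, with a 1.5-fold higher number from compound 1 to compound 2 (0.18 log units; within the scatter). Compound 3 sits at the assay limit (the limit of > 100000 nM in this assay, at which 1 of the 3 values shown sits). Compound 4, `COc1cc(-c2nnc3n2NC(c2ccco2)C(C(=O)c2ccc(O)cc2)S3)cc(OC)c1OC`, differs from compound 1 by 4-hydroxyphenyl in place of 3,4-difluorophenyl on a carbonyl carbon. For the measured compounds named here, the steps that bear on this place are a 1.5-fold higher number from compound 1 to compound 2 (0.18 log units; within the scatter) and an at least 1.9-fold higher number from compound 1 to compound 3 (0.28 log units; that floor lies within the scatter), both within the scatter, so no change beyond the scatter is expected for compound 4 in this assay. Compound 4 is estimated at 70000 nM, with a range of 30000 nM to 160000 nM, which means an expected step of a 1.3-fold higher number from compound 1 to compound 4 (0.13 log units; within the scatter).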

Compound 4, half-maximal inhibitory concentration: > 100000 nM
Compound 4: only a limit was reported (the forecaster's own chance of this, stated with the estimate: 35%); middle value at least 1.4-fold (0.15 log units) away from the limit.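

With 4-hydroxyphenyl on the carbonyl carbon, compound 4 is reported in this assay only as a limit, as compound 3 is: the limit of > 100000 nM in this assay, at which 2 of the 4 values shown sit.

The readable floors are an at least 1.9-fold higher number from compound 1 to compound 4 (0.28 log units; that floor lies within the scatter) and an at least 1.2-fold higher number from compound 2 to compound 4 (0.10 log units; that floor lies within the scatter), and neither goes beyond the scatter; the step between the two limits cannot be read. Among the four compounds, the oxygen-bearing aryl groups sit at the limit, while the halogen-bearing aryl groups of compound 1 and compound 2 give numbers.

As far as these compounds go, the true size of the change from halogen to hydroxy stays open. Also open, from the compounds shown here alone, is whether an amine or a carboxylic acid in place of hydroxy would give a number in this assay.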